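Carbamoyl to 2-phenylethenyl on the shared core

The source may hold more compounds than are shown below. What is called first, only, known or untested is meant among the compounds shown, and "the series" means these compounds.

Values in an ADME assay on HEK293 cells (Homo sapiens) for cytotoxicity, with a stated time of 72 h (a lower number here means that less compound is needed, a higher number that more compound is needed for the effect), all limits:
- compound 1 `C=C[C@@](C)(/C=C/c1ccc(O)c(/C=C/C(=O)O)c1)CCC=C(C)C`, limit > 36600 nM
- compound 2 `C=C[C@@](C)(/C=C/c1ccc(O)c(/C=C/C(N)=O)c1)CCC=C(C)C`, limit > 36600 nM
- compound 3 `C=C[C@@](C)(/C=C/c1ccc(O)c(/C=C/C(=O)NCc2ccc(C(F)(F)F)cc2)c1)CCC=C(C)C`, limit > 36600 nM

Compound 2 stands only at a limit (> 36600 nM) with no number. Compound 4 `C=C[C@@](C)(/C=C/c1ccc(O)c(/C=C/C=C/c2ccccc2)c1)CCC=C(C)C` carries 2-phenylethenyl in place of carbamoyl on a double-bonded chain carbon bound to a double-bonded chain carbon. The steps bearing on this are a step that the two limits leave unreadable from compound 1 to compound 2 and a step that the two limits leave unreadable from compound 2 to compound 3, so neither gives a size. Compound 3, which also carries an added aromatic group, remains at a limit (> 36600 nM). The expected change is a step that the limit leaves unreadable from compound 2 to compound 4, with no direction expected beyond the scatter. The estimated value for compound 4 is 45000 nM (18000 nM to 100000 nM).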

Compound 4, half-maximal effective concentration: > 36600 nM
Compound 4: a limit, no number (the forecaster's own chance of this, stated with the estimate: 75%); the middle value does not contradict the limit.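

Within the data shown here, no step among compound 1, compound 2, compound 3 and compound 4 can be read, as all four stand at a limit and not at a number: the limit of > 36600 nM in this assay, at which 4 of the 4 values shown sit. The compounds shown leave open whether their half-maximal effective concentrations differ at all.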